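From hydroxyhexyl to benzimidazolyl on the amine

The source may report more compounds than this note shows. Statements on the series, on what has been measured and on what is new or still open speak of the compounds shown alone.

Among the compounds with values here, compound 3 `Cc1c(Cc2ccccc2)c(=O)oc2cc(OCC(O)CNCCCCCCO)ccc12` is the one member of this small set with an actual number in an ADME assay on A549 cells (Homo sapiens) for cytotoxicity, read by CellTiter-Glo; a lower number here means that less compound is tolerated, a higher number that more compound is tolerated: compound 3 gives 40300 nM. Compound 1 `Cc1c(Cc2ccccc2)c(=O)oc2cc(OCC(O)CNc3ccccc3)ccc12` reaches only a limit of the assay, > 100000 nM. Compound 2 `Cc1c(Cc2ccccc2)c(=O)oc2cc(OCC(O)CNc3ccc(Br)cc3)ccc12` likewise stops at a limit, > 100000 nM. The steps of an at least 2.4-fold lower number from compound 1 to compound 3 (0.39 log units; beyond the scatter) and an at least 2.4-fold lower number from compound 2 to compound 3 (0.39 log units; beyond the scatter) both replaced an aromatic group on the amine nitrogen with the 6-hydroxyhexyl chain, and both lowered the number. Compound 4 `Cc1c(Cc2ccccc2)c(=O)oc2cc(OCC(O)CNc3nc4ccccc4[nH]3)ccc12` reverses that direction: 1H-benzimidazol-2-yl in place of 6-hydroxyhexyl on an amine nitrogen. An aromatic group returns to the amine nitrogen, so a higher number than compound 3 is expected, possibly reaching (the limit of > 100000 nM in this assay, at which 2 of the 3 values shown sit). Compound 4 is therefore estimated at 80000 nM, between 30000 nM and 200000 nM, which would mean a step of a 2.0-fold higher number from compound 3 to compound 4 (0.30 log units; within the scatter).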

Compound 4, half-maximal cytotoxic concentration: > 100000 nM
Compound 4 was reported as a limit; the forecaster's own chance of this, stated with the estimate: 50%; at least 1.2-fold (0.09 log units) between middle value and limit.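

Putting 1H-benzimidazol-2-yl on this amine nitrogen gives an at least 2.4-fold higher number from compound 3 to compound 4 (0.39 log units; beyond the scatter), so a group with a five-membered aromatic ring holding hetero atoms also restores the higher reading, not only phenyl and 4-bromophenyl. Compound 4 stands at a limit of this assay, and its steps to compound 1 and compound 2 cannot be read. All three aromatic groups now share that one reading, and only the 6-hydroxyhexyl chain of compound 3 differs: the limit of > 100000 nM in this assay, at which 3 of the 4 values shown sit.

Still open, going by these compounds, is whether the lower number follows the chain itself or its hydroxyl. A plain hexyl chain or a cyclohexyl ring on the same nitrogen would separate the two.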